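Phenol for anisole on the aryl arm of compound 2

This account rests on a few compounds, and the source may have more. Where it says the series, first, only, none or still open, it means among the compounds named here.

Going by the values given here, compound 2 `COc1ccc(-c2cc(C)c3ncc(CSCCc4ccccc4)n3c2)cc1` is the one compound with a number in an ADME assay on HEL cells (Homo sapiens) for cytotoxicity, with a stated time of 3 days (on this read-out lower numbers stand for higher toxicity in this test and higher numbers for lower toxicity in this test), where compound 2 gives 25.8 ug/mL. Compound 1 `COc1cccc(-c2cc(C)cn3c(CSCCc4ccccc4)cnc23)c1` gives only a limit in this assay, > 50 ug/mL. Among the compounds with values here, compound 2 therefore stands alone against (the limit of > 50 ug/mL in this assay, at which 1 of the 2 values shown sits), and no step between measured compounds is available as a guide.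

Compound 3 `Cc1cc(-c2cccc(O)c2)cn2c(CSCCc3ccccc3)cnc12` differs from compound 2 by 3-hydroxyphenyl in place of 4-methoxyphenyl on an aromatic carbon, in words 3-hydroxyphenyl in place of 4-methoxyphenyl on an aromatic carbon. With nothing measured for such a swap, the step expected in this assay is a 1.4-fold higher number from compound 2 to compound 3 (0.13 log units; within the scatter), small and not beyond the usual scatter in either direction. Compound 3 is estimated at 35 ug/mL in this assay, with a range from 15 ug/mL to 80 ug/mL, and a fair chance that only a limit is reported.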

Compound 3, half-maximal cytotoxic concentration: 50 ug/mL
Compound 3: middle estimate off by 1.4-fold (0.15 log units), on the low side, within the range that was stated.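

In this assay, the exchange of 4-methoxyphenyl for 3-hydroxyphenyl gives a 1.9-fold higher number from compound 2 to compound 3 (0.29 log units; within the scatter), so this position now has one readable step. That step adds a hydrogen-bond donor and moves the oxygen on the aryl arm, yet the read-out does not shift beyond the scatter. The number for compound 3 stands at the figure where the assay's measured range ends: the limit of > 50 ug/mL in this assay, at which 1 of the 3 values shown sits.

Compound 1 gives only a limit, > 50 ug/mL, so its step to compound 3 cannot be read, and the effect of the oxygen's position on the aryl ring cannot be separated from that of hydroxyl against methoxy. On these data alone, whether an amine or a carboxylic acid on this aryl arm would give a step beyond the scatter remains open.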